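From benzoyl to benzyloxycarbonyl on compound 3

This account rests on a few compounds, and the source may have more. Where it says the series, first, only, none or still open, it means among the compounds named here.

Measured in a functional assay on SEM cells (Homo sapiens) for cytotoxicity, with a stated time of 72 h; on this read-out lower numbers stand for an effect already at smaller amounts and higher numbers for an effect only at larger amounts of compound:
Compound 1 `C=C[C@@](C)(/C=C/c1ccc(O)cc1)CC/C=C/C(=O)OCc1ccccc1`: > 36600 nM (a limit of the assay)
Compound 2 `C=C[C@@](C)(/C=C/c1ccc(O)cc1)CC/C=C(\C)C=O`: > 36600 nM (a limit of the assay)
Compound 3 `C=C[C@@](C)(/C=C/c1ccc(O)c(/C=C/C(=O)c2ccccc2)c1)CCC=C(C)C`: 8000 nM

For the measured compounds named here, compound 3, at 8000 nM, holds the only actual number in the set. Compound 1 and compound 2 stand at the limit of > 36600 nM in this assay, at which 2 of the 3 values shown sit. Compound 4 `C=C[C@@](C)(/C=C/c1ccc(O)c(/C=C/C(=O)OCc2ccccc2)c1)CCC=C(C)C` departs from compound 3 by one change: benzyloxy in place of phenyl on a carbonyl carbon. Going by the values given here, no measured pair isolates this change, so any forecast is loose. Compound 1 also carries benzyloxy on a carbonyl carbon, and its > 36600 nM is a limit. A modest rise in the number is therefore expected in this assay, the estimated step being a 1.8-fold higher number from compound 3 to compound 4 (0.24 log units; within the scatter). For compound 4 the estimated value is 14000 nM, with an expected range of 5000 nM to 36000 nM.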

Compound 4, half-maximal effective concentration: > 36600 nM
Compound 4: only a limit was reported (the forecaster's own chance of this, stated with the estimate: 30%); middle value at least 2.6-fold (0.41 log units) from the limit.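

Benzyloxy in place of phenyl on this carbonyl carbon gives the first one-place comparison in the set, and in this assay it produces an at least 4.5-fold higher number from compound 3 to compound 4 (0.66 log units; beyond the scatter). Compound 4 gives > 36600 nM, which is a limit and not a number, so the step has only a lower bound. Compound 3 therefore remains the only compound with an actual number: the limit of > 36600 nM in this assay, at which 3 of the 4 values shown sit.

As far as these compounds go, the true size of the step stays open. So does the read-out with a methyl ketone, an amide or a carboxylic acid on this carbonyl carbon.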